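A few compounds are considered here, and "the series" means these few. Any claim that something is new, unique, unknown or untested is made for them only; others in the source may bear on it.

Measured compounds:
compound 1 `COc1ccc(-c2cc(=O)c3ccc(OC)cc3o2)cc1`, an in vitro assay on BTI-TN-5B1-4 cells for inhibition of Amine oxidase [flavin-containing] A (Homo sapiens), tested at 100 uM; on this read-out lower numbers stand for less inhibition and higher numbers for more inhibition at the one concentration tested (going by the name of the read-out): "not active" (no number reported)
compound 2 `Fc1ccc2c(=S)cc(-c3ccccc3)oc2c1`, this assay: 40%

In this assay compound 1 gives "not active" (no number reported), so no number marks where it stands; it is reported only as without measurable inhibition at the single concentration tested. For the measured compounds named here, compound 2, a different core carrying fluoro and phenyl, gives 40% in this assay, but no step between compound 1 and compound 2 is computed, and the two share no single-point change.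

Compound 3 `COc1ccc(-c2cc(=O)c3ccc(F)cc3o2)cc1` is the one not yet measured. The change from compound 1 to compound 3 is fluoro in place of methoxy on an aromatic carbon. Going by the values given here, no step between measured compounds of this kind exists, so the size of this step is uncertain. Given that compound 2, which also carries fluoro, shows 40%, an upward step of modest size is expected for compound 3 in this assay, possibly beyond the scatter. For compound 3 the estimated inhibition is 20%, within the range from 0% to 45%.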

Compound 3, a percentage reported as inhibition, at one concentration (the size of the read-out at that concentration, not a potency): 40%
The estimate for compound 3 lay 20 percentage points below the measured number; the measured number falls inside the stated range.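

For the compounds shown here, compound 1 has no reported number, so no step from compound 1 to compound 3 can be read. The compounds shown leave open how large a change fluoro in place of methoxy makes in this assay on the shared core. No measurement here offers an explanation for the result.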